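Notes on the series: substitution at the ring amine nitrogen

The compounds below may be only part of what the source reports. "The series", "measured", "known", "first", "only" and "open" are said of these compounds alone.

Measured so far:
compound 1 `NC(=O)c1c(NC(=O)c2ccccc2Cl)sc2c1CCN(Cc1c(Cl)cccc1Cl)C2` — 28800 nM
compound 2 `NC(=O)c1c(NC(=O)c2ccc(C(F)(F)F)cc2)sc2c1CCN(Cc1c(Cl)cccc1Cl)C2` — reported only as a limit, > 50000 nM

Within the data shown here, in a functional assay on HeLa cells (Homo sapiens) for antiproliferative activity, with a stated time of 24 h (a lower number here means a stronger inhibitor, a higher number a weaker inhibitor), compound 1 gives 28800 nM, the only number so far. For compound 2 this assay reports the limit > 50000 nM (the limit of > 50000 nM in this assay, at which 1 of the 2 values shown sits). Among the measured compounds shown here, the single measured step, an at least 1.7-fold higher number from compound 1 to compound 2 (0.23 log units; that floor lies within the scatter), alters the group on the carbonyl carbon and leaves the ring amine nitrogen untouched, so it does not bear on the change to compound 3.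

Compound 3 `COc1ccc(NC(=S)N2CCc3c(sc(NC(=O)c4ccccc4Cl)c3C(N)=O)C2)cc1` differs from compound 1 by a group of 11 heavy atoms (8 carbon, 1 nitrogen, 1 oxygen, 1 sulfur; one six-membered aromatic ring of carbon only) in place of a group of 9 heavy atoms (7 carbon, 2 chlorine; one six-membered aromatic ring of carbon only), on an amine nitrogen in a ring. For the measured compounds named here, no measured step touches this position, so no direction beyond the scatter can be expected from the data, and the estimate rests on compound 1 alone with a wide range. Compound 3 is expected near 30000 nM, with a range from 8000 nM to 100000 nM. The expected step for compound 3 is therefore a 1.0-fold higher number from compound 1 to compound 3 (0.02 log units; within the scatter).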

Compound 3, half-maximal inhibitory concentration: 36400 nM
The estimate for compound 3 lay 1.2-fold (0.08 log units) below the measured number; the measured number falls inside the stated range.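

In this assay, among these compounds, the first readable step at the amine nitrogen in a ring is a 1.3-fold higher number from compound 1 to compound 3 (0.10 log units; within the scatter). This position therefore accepts the loss of 2,6-dichlorobenzyl and the entry of a group with 1 hydrogen-bond donor, 2 hydrogen-bond acceptors and 1 double bond outside aromatic rings without a change beyond the scatter. This holds only for this pair, with 2-chlorophenyl on the carbonyl carbon.

As far as these compounds go, whether a much smaller group on this nitrogen, such as a methyl group, or a longer chain ending in an amine would move the number beyond the scatter remains open. Compound 2 stays a limit, not a number, and the same exchange at the nitrogen has no counterpart with its 4-(trifluoromethyl)phenyl group: the limit of > 50000 nM in this assay, at which 1 of the 3 values shown sits.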